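This account rests on a few compounds, and the source may have more. Where it says the series, first, only, none or still open, it means among the compounds named here.

Measured so far in a functional assay on QGY7701 cells (Homo sapiens) for cytotoxicity, read by MTT assay, with a stated time of 24 h; on this read-out lower numbers stand for stronger inhibition and higher numbers for weaker inhibition:
compound 1, `C=CC1=C(C(=O)NCCCCC)C(c2ccc(Cl)c(Cl)c2)OC1`: > 100000 nM, which is a limit of the assay and not a number
compound 2, `C=CC1=C(C(=O)NCc2ccc(Cl)cc2)C(c2ccc(F)cc2)OC1`: 36900 nM

Going by the values given here, compound 2 stands as the only real number in this assay; the other entry is a limit, as the limit of > 100000 nM in this assay, at which 1 of the 2 values shown sits, records. The step considered here leads from compound 2 to compound 3, `C=CC1=C(C(=O)NC(C)(C)C)C(c2ccc(F)cc2)OC1`, which has not yet been measured. The change is tert-butyl in place of 4-chlorobenzyl on an amide-type nitrogen, so a ring-bearing group is swapped for a small branched chain while the amide itself is kept. Among the compounds with values here, no step between measured compounds is available to show how this assay responds to such a swap, so the expectation rests on compound 2 alone. The change from compound 2 to compound 3 is expected to be a modest loss, a 1.8-fold higher number from compound 2 to compound 3 (0.25 log units; within the scatter), only a little beyond the usual scatter and leaning toward weaker inhibition. Compound 3 is therefore estimated at 65000 nM in this assay, with a range from 20000 nM to 200000 nM, and a real chance that only a limit is reported.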

Compound 3, half-maximal inhibitory concentration: > 100000 nM
Compound 3 gave a limit, no number; the forecaster's own chance of this, stated with the estimate: 40%; at least 1.5-fold (0.18 log units) between middle value and limit.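

In this assay, going by these compounds alone, replacing 4-chlorobenzyl with tert-butyl on an amide-type nitrogen gives an at least 2.7-fold higher number from compound 2 to compound 3 (0.43 log units; beyond the scatter), the first comparison here in which only one place changes. It shows that the result in this assay depends on the group at this position: the number seen for compound 2 does not carry over once its 4-chlorobenzyl group is gone. The true size of the step stays unknown because the entry for compound 3 is a limit, so the step gives only a minimum: the limit of > 100000 nM in this assay, at which 2 of the 3 values shown sit.

The step also leaves open which feature of the departing group matters, as the ring, the chlorine and the larger count of heavy atoms all leave together, and compound 1 differs from compound 2 in more than one place and so cannot separate them. Plain benzyl without the chlorine, 4-methoxybenzyl or a chain ending in an amine on the same nitrogen would help to tell these apart, and would show whether this position can give a clearly lower number than compound 2 does.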